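The source may report more compounds than this note shows. Statements on the series, on what has been measured and on what is new or still open speak of the compounds shown alone.

Compound 1 `CC(C)n1ncnc1-c1ccccc1NCC1=NCCN1` in an in vitro functional assay on cells (Fibroblast) for agonist activity at Alpha-1B adrenergic receptor (Homo sapiens); a higher number here means that more compound is needed for the effect, a lower number that less compound is needed: < 100000 nM, which is a limit of the assay and not a number.
Compound 2 `CCn1cccc1-c1ccccc1NCC1=NCCN1` in this assay: < 100000 nM, also a limit of the assay.
Compound 3 `CCn1nccc1-c1ccccc1NCC1=NCCN1` in this assay: < 100000 nM, also a limit of the assay.

For compound 1 no exact number is known; its result sits at the limit of < 100000 nM in this assay, at which 3 of the 3 values shown sit, and since the two other shown values are limits as well, nothing can be said about any order among compounds 1, 2 and 3. The change leading to compound 4 `Cn1ncnc1-c1ccccc1NCC1=NCCN1` is a small one: methyl in place of isopropyl on an aromatic nitrogen. Among the measured compounds shown here, with no measured pair to compare, the expected change in this assay is none beyond the usual scatter. Compound 4 is therefore estimated at 5000 nM, with a range from 300 nM to 50000 nM. The step this estimate implies, a step that the limit leaves unreadable from compound 1 to compound 4, is an expectation only.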

Compound 4, half-maximal effective concentration: 39.8 nM
The estimate for compound 4 lay 130-fold (2.10 log units) above the measured number; measured number outside the range, below it.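

Among the compounds shown here, no step from compound 1 to compound 4 can be read, because the result for compound 1 is a limit of the assay and not a number: the limit of < 100000 nM in this assay, at which 3 of the 4 values shown sit.
In this assay the compounds shown leave open how much methyl in place of isopropyl on an aromatic nitrogen changes the result.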